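The source may hold more compounds than are shown below. What is called first, only, known or untested is meant among the compounds shown, and "the series" means these compounds.

Measured so far in an assay on microsomes from intestine for inhibition of acyl-CoA:cholesterol acyltransferase (Oryctolagus cuniculus); a lower number here means a stronger inhibitor, a higher number a weaker inhibitor: compound 1 `CC(C)c1cccc(C(C)C)c1NC(=O)NCC1(c2ccsc2)CCCC1`, 18 nM; compound 2 `COc1ccccc1NC(=O)NCC1(c2ccccc2)CCCCC1`, 270 nM; compound 3 `Cc1ccccc1NC(=O)NCC1(c2ccccc2)CCCCC1`, 640 nM.

Among the measured compounds shown here, compound 3 carries the highest of these three numbers: the step of a 2.4-fold higher number from compound 2 to compound 3 (0.37 log units; beyond the scatter) is the only single-place change among the measured compounds, while compound 1, at 18 nM, stands far lower and differs in several places at once. Compound 4 `O=C(NCC1(c2ccccc2)CCCCC1)Nc1ccccc1C(F)(F)F` differs from compound 3 by trifluoromethyl in place of methyl on an aromatic carbon. For the measured compounds named here, the only measured change of that kind, a 2.4-fold higher number from compound 2 to compound 3 (0.37 log units; beyond the scatter), was modest, and no measured pair exchanges methyl for trifluoromethyl, so the guidance is thin. A step of a 1.3-fold lower number from compound 3 to compound 4 (0.11 log units; within the scatter) is therefore expected, roughly within the scatter. In this assay compound 4 is expected to give 500 nM, in the range 150 nM to 1800 nM.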

Compound 4, half-maximal inhibitory concentration: 200 nM
Estimate against measurement, compound 4: 2.5-fold (0.40 log units) above; measured number inside the range.
By their numbers in this assay, from the lowest: compound 1; then compounds 4 and 2 (each within the scatter of the next); then compound 3.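

In this assay, trifluoromethyl on this aromatic carbon, ortho to a large group, beats methyl, with a 3.2-fold lower number from compound 3 to compound 4 (0.51 log units; beyond the scatter) as the step. Set against methoxy, the same group gives a 1.4-fold lower number from compound 2 to compound 4 (0.13 log units; within the scatter) as the step, so those two cannot be told apart and methyl alone stands off from them among the three groups seen here. Nothing measured here explains this ranking. Still open, as far as these compounds go, is whether an amine, a chlorine atom or a longer chain at this place would match them. Also open, from the compounds shown here alone, is whether the exchange of methyl for trifluoromethyl would do the same on the core of compound 1.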